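The source may hold more compounds than are shown below. What is called first, only, known or untested is meant among the compounds shown, and "the series" means these compounds.

In a functional assay on A549 cells (Homo sapiens) for cytotoxicity, read by MTT assay, with a stated time of 48 h (a higher number here means a more soluble compound, a lower number a less soluble compound), compound 2 `O=C(N/N=C/c1ccccc1O)c1cc(-c2ccc(Cl)cc2)nn1Cc1ccccc1` gives 25000 nM; its one companion, compound 1 `O=C(N/N=C/c1ccccc1O)c1cc(-c2ccc(Cl)cc2)nn1Cc1ccc(Cl)nc1`, gives 22500 nM in this assay, and the step of a 1.1-fold higher number from compound 1 to compound 2 (0.05 log units; within the scatter) lies within the scatter, so compound 2 stands level with compound 1. Compound 3 `CC(C)(C)c1ccc(Cn2nc(-c3ccc(Cl)cc3)cc2C(=O)N/N=C/c2ccccc2O)cc1` differs from compound 2 by tert-butyl in place of hydrogen on an aromatic carbon. For the measured compounds named here, no measured step covers this change; the only step recorded, a 1.1-fold higher number from compound 1 to compound 2 (0.05 log units; within the scatter), also reshapes the group on the saturated chain carbon bound to the aromatic nitrogen and stayed within the scatter. The step of a 1.0-fold lower number from compound 2 to compound 3 (0.02 log units; within the scatter) is therefore expected to stay within the scatter as well. For compound 3 the estimate is 24000 nM, with a range from 11000 nM to 50000 nM.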

Compound 3, solubility: 36000 nM
Beside the measured number, compound 3's estimate is 1.5-fold (0.18 log units) below it; the measured number falls inside the stated range.
By their numbers in this assay, from the lowest: compounds 1, 2 and 3 (each within the scatter of the next).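

In this assay, tert-butyl in place of hydrogen on this aromatic carbon gives a 1.4-fold higher number from compound 2 to compound 3 (0.16 log units; within the scatter), and the wider exchange of 6-chloropyridin-3-yl for 4-(tert-butyl)phenyl gives a 1.6-fold higher number from compound 1 to compound 3 (0.20 log units; within the scatter). The earlier pair changed only the ring on the saturated chain carbon, whereas these steps show that a group of 4 heavy atoms at this position leaves the number within the scatter. No evidence bearing on this result is available. The compounds shown leave open whether an amine, a carboxylic acid or a longer chain in place of tert-butyl would also stay within the scatter.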